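Chloro Added to a Methoxy Sulfonamide: Cytotoxicity Expectation

The compounds below may be only part of what the source reports. "The series", "measured", "known", "first", "only" and "open" are said of these compounds alone.

Compound 1 `Cc1ccc(S(=O)(=O)Nc2nnc(SCc3ccc(Cl)cc3)s2)cc1`: 70%
Compound 2 `COc1ccc(S(=O)(=O)Nc2nnc(SCc3ccccc3)s2)cc1`: 57%

Both measured compounds were tested in a toxicity assay on HaCaT cells (Homo sapiens) for cytotoxicity, tested at 250 uM; a higher number here means a weaker effect of the compound at the concentration tested, a lower number a stronger effect. Compound 2 stands at the lower of the two numbers, with compound 1 coming out higher by a margin beyond the usual scatter; the two differ in more than one place, so nothing further is read from that pair. Compound 3 `COc1ccc(S(=O)(=O)Nc2nnc(SCc3ccc(Cl)cc3)s2)cc1` arises from compound 2 through one change: chloro in place of hydrogen on an aromatic carbon. Among the compounds with values here, no measured pair shows this change on its own, so the step of a number 6 percentage points higher from compound 2 to compound 3 (within the scatter) is expected to be small, if any, leaning slightly upward. Compound 3 is therefore estimated at 63%, within 45% to 82%.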

Compound 3, a percentage reported as activity, at one concentration (the size of the read-out at that concentration, not a potency): 79%
The estimate for compound 3 lay 16 percentage points below the measured number; the measured number falls inside the stated range.
By their numbers in this assay, from the lowest: compound 2; then compounds 1 and 3 (each within the scatter of the next).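

In this assay, within the data shown here, the change from benzyl to 4-chlorobenzyl gives a number 22 percentage points higher from compound 2 to compound 3 (beyond the scatter), the first reading of chloro on its own at this place, and with methoxy present it weakens the effect at the concentration tested. With the 4-chlorobenzyl kept, methoxy in place of methyl gives a number 9 percentage points higher from compound 1 to compound 3 (within the scatter), so that swap shows no clear change. Nothing measured here gives a reason for the chloro step. Open, on these data alone, is whether the chloro step also holds with methyl in place of methoxy, and whether a bromo or an amine at the same place would behave like chloro.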